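Swapping a thiazole for a pyridine in a TRPM8 agonist

The source may hold more compounds than are shown below. What is called first, only, known or untested is meant among the compounds shown, and "the series" means these compounds.

Of the compounds shown here, two sharing one core have been measured so far. Compound 1 `CCN(Cc1cncs1)C(=O)COc1ccc(C)cc1` carries a 1,3-thiazol-5-yl group on the saturated chain carbon bound to the amide-type nitrogen, and in an assay on HEK293 cells for agonist activity at transient receptor potential cation channel subfamily M member 8 (Homo sapiens), read by fluorescence and calcium flux, with a stated time of 15 min (on this read-out higher numbers stand for an effect only at larger amounts of compound and lower numbers for an effect already at smaller amounts), compound 1 gives 1100 nM. Compound 2 `CCN(Cc1cccs1)C(=O)COc1ccc(C(C)C)cc1` differs in more than one place, and in this assay compound 2 gives 397 nM. Of these two numbers, compound 1 has the higher one, and the gap between them lies beyond the usual scatter of repeated measurements.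

Compound 3 `CCN(Cc1ccccn1)C(=O)COc1ccc(C)cc1` is the next structure to be examined. Its change from compound 1 is pyridin-2-yl in place of 1,3-thiazol-5-yl on a saturated chain carbon bound to an amide-type nitrogen. Within the data shown here, only two measured compounds exist and no single-change comparison links them, so there is no directly comparable precedent for this swap; the expectation for compound 3 leans on the value of compound 1 at 1100 nM. The step from compound 1 to compound 3 in this assay is expected to be small, a 1.2-fold lower number from compound 1 to compound 3 (0.09 log units; within the scatter), without a confident direction. Compound 3 is therefore estimated at 900 nM, with a plausible range from 300 nM to 2700 nM.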

Compound 3, half-maximal effective concentration: 16000 nM
Compound 3: middle estimate off by 18-fold (1.25 log units), on the low side; measured number outside the range, above it.
By their numbers in this assay, from the lowest: compound 2; then compound 1; then compound 3.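

In this assay, the group on the saturated chain carbon bound to an amide-type nitrogen turns out to matter a great deal: pyridin-2-yl in place of 1,3-thiazol-5-yl brings a 15-fold higher number from compound 1 to compound 3 (1.16 log units; beyond the scatter), so far more compound is needed for the same effect. Among these compounds, this is the first comparison here in which only one place changes, and it shows that two aromatic rings, each holding a ring nitrogen and neither carrying a hydrogen-bond donor, cannot simply stand in for each other at this position. Nothing available on these compounds explains why the step is so large.

The single step changes several things at once, going from a five-membered to a six-membered ring and dropping the sulfur, so the compounds shown cannot tell which of these differences goes with the higher number. From the compounds shown here alone, a phenyl group at the same place, with no ring nitrogen at all, would be one way to begin separating these differences, and its effect remains open.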